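The compounds below may be only part of what the source reports. "The series", "measured", "known", "first", "only" and "open" are said of these compounds alone.

Measured compounds in a functional assay on MCF7 cells (Homo sapiens) for inhibition, read by MTT assay, with stated times of 18 h and 4 h; on this read-out higher numbers stand for weaker inhibition and lower numbers for stronger inhibition:
- compound 1, `CCCCCCCCCCCCCCCCOP(=O)(O)OCCSC(=S)N1CCCCC1`: 29000 nM
- compound 2, `CCCOP(=O)(O)OCCSC(=S)N1CCCC1`: 73000 nM
- compound 3, `CCCCCCCCOP(=O)(O)OCCSC(=S)N1CCCCCC1`: 78000 nM

Compound 3 stands at the highest of the three numbers shown. Its nearest neighbour is compound 2, whose number lies within the scatter of compound 3's, so the two cannot be told apart on this read-out. Compound 1 lies furthest from compound 3, with a lower number beyond the scatter, and so shows stronger inhibition than compound 3.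

Compound 4, `CCCOP(=O)(O)OCCSC(=S)N1CCCCCC1`, has not yet been measured in this assay. It differs from compound 3 in one place: hydrogen in place of pentyl on a saturated chain carbon, three bonds along the chain from an oxygen on an unsaturated carbon. The same difference, cut one bond further out, reads octyl to propyl.

Among the measured compounds shown here, no step between measured compounds that differ in one place is available, so the size of this change has to be expected rather than read off. Compound 2 carries a propyl chain and compound 3 an octyl chain, and their numbers in this assay sit within the scatter of each other, which suggests that shortening the chain on compound 3 need not move the number far. Compound 4 is therefore expected to stay close to compound 3, with the step from compound 3 to compound 4 estimated as a 1.0-fold higher number from compound 3 to compound 4 (0.01 log units; within the scatter), in no direction beyond the scatter. The estimate for compound 4 in this assay is 80000 nM, with a range from 35000 nM to 180000 nM.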

Compound 4, half-maximal inhibitory concentration: 74000 nM
For compound 4 the middle estimate is 1.1-fold (0.03 log units) above the measured one; the range from low to high includes it.
By their numbers in this assay, from the lowest: compound 1; then compounds 2, 4 and 3 (each within the scatter of the next).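

In this assay, among the compounds shown here, compound 3 and compound 4 form the first pair that differs in one place, so the size of this change can now be read directly: hydrogen in place of pentyl, which shortens octyl to propyl, gives a 1.1-fold lower number from compound 3 to compound 4 (0.02 log units; within the scatter) and so does not separate the two compounds on this read-out. At this position, on a saturated chain carbon, three bonds along the chain from an oxygen on an unsaturated carbon, losing the pentyl therefore leaves no measurable mark while the rest of compound 3 stays the same. No information is available here on what lies behind this result.

This single pair speaks only for the span from octyl to propyl on this one core, so it leaves open whether a longer chain, such as the hexadecyl of compound 1, would change the number with the rest of compound 3 kept in place, since compound 1 differs from compound 3 in more than one place. Also open, from the compounds shown here alone, is how the number would respond to a chain ending in an amine or a carboxylic acid at this position.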